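The source may report more compounds than this note shows. Statements on the series, on what has been measured and on what is new or still open speak of the compounds shown alone.

Compound 3 `CCCNC(=O)/N=C(\N)NCCCc1sc(N)nc1C` stands second highest of the three values in a functional assay on HEK293T cells for agonist activity at histamine H2 receptor (Homo sapiens), read by beta-arrestin recruitment (on this read-out higher numbers stand for an effect only at larger amounts of compound and lower numbers for an effect already at smaller amounts), where compound 3 gives 170 nM. Compound 1 `Cc1nc(N)sc1CCCN/C(N)=N/C(=O)N[C@H](C)c1ccccc1` gives 45.7 nM, and compound 2 `Cc1nc(N)sc1CCCN/C(N)=N/C(=O)NCC(C)CCc1ccccc1` gives 355 nM. Compound 4 `CCCCCCNC(=O)/N=C(\N)NCCCc1sc(N)nc1C` differs from compound 3 by propyl in place of hydrogen on a saturated chain carbon, three bonds along the chain from an amide-type nitrogen. Among the measured compounds shown here, two measured steps bear on a longer group at this nitrogen: a 3.7-fold higher number from compound 1 to compound 3 (0.57 log units; beyond the scatter) shows that a larger substituent lowered the number, whereas a 2.1-fold lower number from compound 2 to compound 3 (0.32 log units; beyond the scatter) shows that more bulk on the chain raised it. Their pull is opposite, so compound 4 is expected to show a modest step at most, a 1.7-fold lower number from compound 3 to compound 4 (0.23 log units; within the scatter), leaning toward a lower number. Compound 4 is therefore estimated at 100 nM, within 40 nM to 300 nM.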

Compound 4, half-maximal effective concentration: 85.1 nM
The estimate for compound 4 lay 1.2-fold (0.07 log units) above the measured number; low and high end bracket the measured number.
By their numbers in this assay, from the lowest: compounds 1, 4 and 3 (each within the scatter of the next, the first and the last beyond it); then compound 2.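

Replacing hydrogen with propyl at this position, which turns the propyl of compound 3 into the hexyl of compound 4, gives a 2.0-fold lower number from compound 3 to compound 4 (0.30 log units; within the scatter) and so leaves the chain extension without a step that can be told from the scatter. Hexyl in place of 1-phenylethyl gives a 1.9-fold higher number from compound 1 to compound 4 (0.27 log units; within the scatter) and so separates a chain with no ring from the 1-phenylethyl group no better. Nothing available explains either step. Going by these compounds, whether a longer chain than hexyl, or an amine or a carboxylic acid at the chain end, would move the number beyond the scatter remains open.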